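Swapping the aryl group on a shared sulfonyl core

The source may report more compounds than this note shows. Statements on the series, on what has been measured and on what is new or still open speak of the compounds shown alone.

Measured compounds and their values in an ADME assay on microsomes from liver (Homo sapiens) for metabolic stability, tested at 2.5 uM; a higher number here means faster removal of the compound, a lower number slower removal:
compound 1, `O=S(=O)(c1cc(F)cc(F)c1)c1cnc2c(F)cccc2c1-c1ccccc1F`, gives 0.09 mL/min
compound 2, `COc1cccc(-c2c(S(=O)(=O)c3cc(F)cc(F)c3)cnc3c(F)cccc23)c1`, gives 2.76 mL/min
compound 3, `COc1cccc(-c2c(S(=O)(=O)c3cccc(C#N)c3)cnc3cc(F)ccc23)c1`, gives 1.83 mL/min

The change from compound 2 to compound 1 is 2-fluorophenyl in place of 3-methoxyphenyl on an aromatic carbon, and it produced a 31-fold lower number from compound 2 to compound 1 (1.49 log units; beyond the scatter). Compound 3 and compound 2 differ in their cores, and that difference is not broken down here; in this assay compound 3 stands near compound 2 and far from compound 1. Compound 4, `N#Cc1cccc(S(=O)(=O)c2cnc3cc(F)ccc3c2-c2ccccc2F)c1`, is not yet measured. It differs from compound 3 by 2-fluorophenyl in place of 3-methoxyphenyl on an aromatic carbon, the same change at the same place as between compound 2 and compound 1. Because that earlier change gave a 31-fold lower number from compound 2 to compound 1 (1.49 log units; beyond the scatter), a step in the same direction is expected, though the different core may alter its size. A step of an 18-fold lower number from compound 3 to compound 4 (1.26 log units; beyond the scatter) is expected on that basis. Compound 4 is therefore estimated at 0.1 mL/min, with a likely range from 0.03 mL/min to 0.5 mL/min.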

Compound 4, intrinsic clearance in a liver preparation (reported as CLH), per the amount of preparation that the assay uses: 1.39 mL/min
For compound 4 the middle estimate is 14-fold (1.14 log units) below the measured one; the whole stated range lies below it.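

In this assay putting 2-fluorophenyl in place of 3-methoxyphenyl on the second core gave a 1.3-fold lower number from compound 3 to compound 4 (0.12 log units; within the scatter) and so left no readable difference there. The large step seen on the first core therefore did not carry over in size, and the outcome of this change depended on the core in these two pairs: the same change on two cores in this assay, a 31-fold lower number (1.49 log units; beyond the scatter) from compound 2 to compound 1 and a 1.3-fold lower number (0.12 log units; within the scatter) from compound 3 to compound 4, 23-fold (1.37 log units) apart, beyond the scatter of two such steps

This does not show which difference between the two cores is responsible, and no pair shown separates those differences. The compounds shown leave open how the change would behave on a third core. They also leave open how the number would respond to an amine or a carboxylic acid on that aromatic carbon in place of either aryl group.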